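Compound 4 Follows Two Level Neighbours

This account rests on a few compounds, and the source may have more. Where it says the series, first, only, none or still open, it means among the compounds named here.

Growth data from a functional assay on DU-145 cells (Homo sapiens) for inhibition, read by trypan blue exclusion, with a stated time of 96 h (on this read-out higher numbers stand for weaker inhibition of growth and lower numbers for stronger inhibition of growth), are available for three compounds
- compound 1 `Cc1ccc(/C=C(/SCc2ccc(Cl)cc2Cl)C(=O)c2ccc(Cl)cc2)s1` gives 50000 nM
- compound 2 `Cc1ccc(CS(=O)(=O)/C(=C/c2ccc(S(C)(=O)=O)cc2)C(=O)c2ccc(Br)cc2)cc1` gives 10000 nM
- compound 3 `COc1cc(/C=C(/Sc2ccc(Br)cc2)C(=O)c2ccc(Br)cc2)ccc1F` gives 10000 nM

Compound 3 stands level with compound 2, the two sharing the lowest number of the three, while compound 1 stands higher. Compound 4 `O=C(/C(=C\c1ccc(F)cc1F)Sc1ccc(Br)cc1)c1ccc(Br)cc1` has not yet been measured. It differs from compound 3 by 2,4-difluorophenyl in place of 4-fluoro-3-methoxyphenyl on a double-bonded chain carbon bound to a double-bonded chain carbon, with 2,4-difluorophenyl in place of 4-fluoro-3-methoxyphenyl on a double-bonded chain carbon bound to a double-bonded chain carbon. Within the data shown here, no measured pair isolates this change, so with compound 3 at 10000 nM no shift beyond the scatter is expected in this assay in either direction. The expected move is no change at the digits printed from compound 3 to compound 4 (within the scatter) and no more. Compound 4 is expected at 10000 nM, within an estimated range of 3000 nM to 30000 nM overall.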

Compound 4, concentration for 50% growth inhibition: 1000 nM
Estimate against measurement, compound 4: 10-fold (1.00 log units) above; measured number outside the range, below it.
By their numbers in this assay, from the lowest: compound 4; then compounds 2 and 3 (each within the scatter of the next); then compound 1.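

In this assay, 2,4-difluorophenyl in place of 4-fluoro-3-methoxyphenyl on a double-bonded chain carbon bound to a double-bonded chain carbon gives a 10-fold lower number from compound 3 to compound 4 (1.00 log units; beyond the scatter). Among these compounds, this position therefore responds to the choice of aromatic group, which the earlier compounds, with no single-place step among them, could not show. Nothing measured here accounts for the step.

The compounds shown leave open whether the lower number goes with the added fluorine or with the lost methoxy group, which change together here. Going by these compounds, how an amine or a carboxylic acid on this ring would read also remains open.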